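Swapping the thiophene attachment on a chloropyridine-free reading

The compounds below may be only part of what the source reports. "The series", "measured", "known", "first", "only" and "open" are said of these compounds alone.

Correction: the title above is wrong, and the piece below replaces it.

From thiophen-3-yl to 4-methylthiophen-2-yl

Within the data shown here, in a functional assay on MV4-11 cells (Homo sapiens) for inhibition, read by resazurin assay, with a stated time of 72 h (a lower number here means a stronger inhibitor of growth, a higher number a weaker inhibitor of growth), compound 1 (`O=C1NCCC12CCN(c1c(Cl)cncc1-c1ccsc1)CC2`) gives 190 nM and holds the lower of the two numbers so far. Among the measured compounds shown here, compound 2 (`O=C1NCCC12CCN(c1c(Cl)cncc1-c1cc[nH]c1)CC2`) gives 1050 nM and supplies the only measured step, a 5.5-fold higher number from compound 1 to compound 2 (0.74 log units; beyond the scatter), made at the same place. Unmeasured compound 3 (`Cc1csc(-c2cncc(Cl)c2N2CCC3(CCNC3=O)CC2)c1`) carries 4-methylthiophen-2-yl in place of thiophen-3-yl on an aromatic carbon and keeps the shared core. Its ring still holds 1 sulfur, so a rise smaller than a 5.5-fold higher number from compound 1 to compound 2 (0.74 log units; beyond the scatter) is expected in this assay. The estimated step is a 1.7-fold higher number from compound 1 to compound 3 (0.23 log units; within the scatter), though this remains uncertain. Compound 3 is expected near 320 nM, with an estimated range of 100 nM to 1000 nM.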

Compound 3, concentration for 50% growth inhibition: 650 nM
Compound 3: middle estimate off by 2.0-fold (0.31 log units), on the low side, and the stated range covers the measured number.
By their numbers in this assay, from the lowest: compound 1; then compounds 3 and 2 (each within the scatter of the next).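

The change to 4-methylthiophen-2-yl gives a 3.4-fold higher number from compound 1 to compound 3 (0.53 log units; beyond the scatter) even though the ring keeps its sulfur, so this position responds to more than the swap of sulfur for nitrogen seen with 1H-pyrrol-3-yl. The change from 1H-pyrrol-3-yl to 4-methylthiophen-2-yl gives a 1.6-fold lower number from compound 2 to compound 3 (0.21 log units; within the scatter) and does not separate these two groups. No supporting measurement accounts for either step.

Going by these compounds, compound 3 differs from compound 1 in both the added methyl and the thiophene attachment point, and the effect of each alone remains open. On these data alone, how a phenyl ring or an aminomethyl group would behave here also remains open.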